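Nitro in Place of Bromo on a Second Core

The source may hold more compounds than are shown below. What is called first, only, known or untested is meant among the compounds shown, and "the series" means these compounds.

Four close relatives of one scaffold are compared for how gently they treat cells, in an ADME assay on MDCK cells (Canis lupus familiaris) for cytotoxicity, read by MTT assay, with a stated time of 48 h; on this read-out higher numbers stand for lower toxicity in this test and lower numbers for higher toxicity in this test. Compound 1, `C[C@@H]1CC[C@@H]2[C@@H](C1)O[C@@H](c1ccc(Br)cc1)CC2(C)O`, carries bromo on an aromatic carbon and hydroxy on a saturated ring carbon; in this assay compound 1 gives 132000 nM. Compound 2, `C[C@@H]1CC[C@@H]2[C@@H](C1)O[C@@H](c1ccc([N+](=O)[O-])cc1)CC2(C)O`, differs from compound 1 by nitro in place of bromo on an aromatic carbon. For compound 2 this assay reports only a limit, > 982000 nM. That exchange gave an at least 7.4-fold higher number from compound 1 to compound 2 (0.87 log units; beyond the scatter), a step that rests on (the limit of > 982000 nM in this assay, at which 1 of the 3 values shown sits). Compound 3, `C[C@@H]1CC[C@@H]2[C@@H](C1)O[C@@H](c1ccc(Br)cc1)CC2(C)F`, keeps the bromo and differs from compound 1 by fluoro in place of hydroxy on a saturated ring carbon. For compound 3 this assay again reports only a limit, > 882000 nM. This second exchange gave an at least 6.6-fold higher number from compound 1 to compound 3 (0.82 log units; beyond the scatter), a step that rests on (the limit of > 882000 nM in this assay, at which 1 of the 3 values shown sits).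

Compound 4, `C[C@@H]1CC[C@@H]2[C@@H](C1)O[C@@H](c1ccc([N+](=O)[O-])cc1)CC2(C)F`, is not yet measured. It differs from compound 3 by nitro in place of bromo on an aromatic carbon, the same change that took compound 1 to compound 2, with the two cores differing as described above. Compound 3 already sits at a limit, and the same exchange on compound 1 reached a limit as well. On that footing compound 4 is expected to show a step that the limit leaves unreadable from compound 3 to compound 4, a step that can hardly be large in either direction from what is visible. The estimated value for compound 4 is 1000000 nM, with a range from 500000 nM to 2000000 nM, and it is expected most likely to be reported once more only as a limit.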

Compound 4, half-maximal cytotoxic concentration: > 976000 nM
Compound 4 ended at the assay's limit (the forecaster's own chance of this, stated with the estimate: 85%); the middle value does not contradict the limit.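

Compound 4 is reported only as a limit, > 976000 nM. Compound 2 and compound 3 are limits as well, so neither the step from compound 3 to compound 4 nor the step from compound 2 to compound 4 can be read. The compounds shown leave open how far apart compound 2, compound 3 and compound 4 really lie in this test.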